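Lengthening the Fluorinated Chain on a Nitrone Triazole

The source may report more compounds than this note shows. Statements on the series, on what has been measured and on what is new or still open speak of the compounds shown alone.

Compound 1 `[O-]/[N+](=C\c1cn(CCC(F)(F)C(F)(F)C(F)(F)C(F)(F)C(F)(F)C(F)(F)C(F)(F)C(F)(F)F)nn1)c1ccccc1`: in a functional assay on A549 cells (Homo sapiens) for inhibition, read by MTT assay, with a stated time of 24 h (a lower number here means a stronger inhibitor, a higher number a weaker inhibitor), compound 1 gives 86800 nM
Compound 2 `[O-]/[N+](=C\c1cn(CCC(F)(F)C(F)(F)C(F)(F)C(F)(F)C(F)(F)C(F)(F)C(F)(F)C(F)(F)F)nn1)Cc1ccccc1`: in this assay compound 2 gives 8800 nM
Compound 3 `CC(C)(C)/[N+]([O-])=C/c1cn(CCC(F)(F)C(F)(F)C(F)(F)C(F)(F)C(F)(F)C(F)(F)F)nn1`: in this assay compound 3 gives 11500 nM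

All three compounds share a core that carries a nitrone and a long fluorinated chain. Within the data shown here, the single measured step that alters one place is a 9.9-fold lower number from compound 1 to compound 2 (0.99 log units; beyond the scatter). Compound 3 stands second highest of the three numbers: its value and that of compound 2 lie within the usual scatter of each other, while compound 1 gives a clearly higher number.

Compound 4 `CC(C)(C)/[N+]([O-])=C/c1cn(CCC(F)(F)C(F)(F)C(F)(F)C(F)(F)C(F)(F)C(F)(F)C(F)(F)C(F)(F)F)nn1` differs from compound 3 only in the chain: 1,1,2,2,2-pentafluoroethyl in place of fluoro on a saturated chain carbon bound to two fluorine atoms and a saturated chain carbon. Among the measured compounds shown here, no measured step touches the chain; the one measured step concerns the group on the double-bonded nitrogen. Compounds 1 and 2 do carry the longer chain, but each also differs from compound 3 at that nitrogen, so their values cannot separate the two changes. The step from compound 3 to compound 4 is therefore expected to stay within the scatter, a 1.0-fold lower number from compound 3 to compound 4 (0.02 log units; within the scatter). Compound 4 is expected to give about 11000 nM in this assay, in a range from 4000 nM to 30000 nM.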

Compound 4, half-maximal inhibitory concentration: 30500 nM
Compound 4: middle estimate off by 2.8-fold (0.44 log units), on the low side, outside the stated range (above it).
By their numbers in this assay, from the lowest: compounds 2 and 3 (each within the scatter of the next); then compound 4; then compound 1.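

In this assay, among these compounds, the change to the chain, 1,1,2,2,2-pentafluoroethyl in place of fluoro, gives a clear move towards a weaker inhibitor (a 2.7-fold higher number from compound 3 to compound 4 (0.42 log units; beyond the scatter)), so chain length matters here even though the earlier compounds could not show it. With the chain now the same, the group on the double-bonded nitrogen can also be judged alone: tert-butyl in place of benzyl weakens inhibition (a 3.5-fold higher number from compound 2 to compound 4 (0.54 log units; beyond the scatter)), whereas tert-butyl in place of phenyl strengthens it (a 2.8-fold lower number from compound 1 to compound 4 (0.45 log units; beyond the scatter)), which places tert-butyl between the other two groups. Nothing available explains why either change acts as it does.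

A single chain step cannot show whether a still longer fluorinated chain would continue this trend. On these data alone, how a plain octyl chain without fluorine, or an amine on the chain end, would behave also stays open.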